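The compounds below may be only part of what the source reports. "The series", "measured", "known", "first", "only" and "open" are said of these compounds alone.

The measured compounds:
compound 1 `CC(C)c1onc(-c2c(Cl)cccc2Cl)c1COc1ccc(N(C)Cc2cccc(C(=O)NS(C)(=O)=O)c2)c(C(F)(F)F)n1`; in a functional assay on HEK293 cells for agonist activity at Bile acid receptor (Homo sapiens), read by a luciferase reporter (on this read-out lower numbers stand for smaller maximal responses and higher numbers for larger maximal responses), compound 1 gives 72%.
compound 2 `CC(c1ccc(OCc2c(-c3c(Cl)cccc3Cl)noc2C2CC2)nc1C(F)(F)F)N(C)c1ccc(C(=O)O)cc1`; in this assay compound 2 gives 57%.
compound 3 `O=C(O)c1ccccc1OCc1ccc(OCc2c(-c3c(Cl)cccc3Cl)noc2C2CC2)nc1C(F)(F)F`; in this assay compound 3 gives 33%.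

Compound 3 gives the lowest of the three numbers. Its nearest neighbour is compound 2, whose value is higher by more than the usual scatter; compound 1 lies furthest away, with a still wider gap, also beyond the scatter. Among the measured compounds shown here, compound 3 shares with compound 2 the same core, but the two differ at several places at once, so no single-change step between them can be read off.

Compound 4 `CC(Oc1cccc(C(=O)O)c1)c1ccc(OCc2c(-c3c(Cl)cccc3Cl)noc2C2CC2)nc1C(F)(F)F` has not yet been measured. It differs from compound 3 in one place: 1-(3-carboxyphenoxy)ethyl in place of (2-carboxyphenoxy)methyl on an aromatic carbon. Because compound 3 gives 33% and compound 2 with its carboxyphenyl group and 1-aryl-ethyl linkage gives 57%, the step is expected to run upward, though only modestly. The estimated step is a number 12 percentage points higher from compound 3 to compound 4 (beyond the scatter). For compound 4 the estimated value in this assay is 45%, within a range from 25% to 68%.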

Compound 4, largest response reached (reported as efficacy), in percent of the reference or control that the assay uses: 49%
For compound 4 the middle estimate is 4 percentage points below the measured one; the range from low to high includes it.
By their numbers in this assay, from the lowest: compound 3; then compounds 4 and 2 (each within the scatter of the next); then compound 1.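

At the aromatic carbon two atoms from the ring nitrogen, 1-(3-carboxyphenoxy)ethyl in place of (2-carboxyphenoxy)methyl gives, in this assay, a number 16 percentage points higher from compound 3 to compound 4 (beyond the scatter), which shows that the maximal response depends on the group held at this position. At the saturated chain carbon, 3-carboxyphenoxy in place of (4-carboxyphenyl)(methyl)amino gives a number 8 percentage points lower from compound 2 to compound 4 (within the scatter), so this assay does not separate these two groups there. No measurement at hand explains either step.

The compounds shown leave open whether the rise belongs to 3-carboxyphenoxy in place of 2-carboxyphenoxy or to ethyl in place of methyl, as both differences come within one step. They also leave open how this assay would respond at this position to a tetrazole or a primary amide in place of the carboxylic acid.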